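This account rests on a few compounds, and the source may have more. Where it says the series, first, only, none or still open, it means among the compounds named here.

Compound 1, `CCN(CC)CCn1c(N)c(-c2nc3ccccc3[nH]2)c2nc(C#N)c(C#N)nc21`, gives 8950 nM in a functional assay on Raji cells (Homo sapiens) for antiproliferative activity, read by MTT assay, with a stated time of 48 h; on this read-out lower numbers stand for stronger inhibition and higher numbers for weaker inhibition. Compound 2, `CN(C)CCCn1c(N)c(-c2nc3ccccc3[nH]2)c2nc(C#N)c(C#N)nc21`, gives 1230 nM in this assay. Compound 3, `CCN(CC)CCCn1c(N)c(-c2nc3ccccc3n2C)c2nc(C#N)c(C#N)nc21`, gives 2220 nM in this assay.

Between compound 1 and compound 2 the change is (dimethylamino)methyl in place of diethylamino on a saturated chain carbon, two bonds along the chain from an aromatic nitrogen, and it brought a 7.3-fold lower number from compound 1 to compound 2 (0.86 log units; beyond the scatter). The number for compound 3 lies nearest that of compound 2 and furthest from that of compound 1; the difference between the core of compound 1 and the core of compound 3 is not broken down here. Compound 4, `CN(C)CCCCn1c(N)c(-c2nc3ccccc3n2C)c2nc(C#N)c(C#N)nc21`, has not been measured. It differs from compound 3 by (dimethylamino)methyl in place of diethylamino on a saturated chain carbon, three bonds along the chain from an aromatic nitrogen. This is the same kind of change as that from compound 1 to compound 2, not the same, since the place is three bonds along the chain from an aromatic nitrogen rather than two, and the cores are not alike. Because the step of a 7.3-fold lower number from compound 1 to compound 2 (0.86 log units; beyond the scatter) lay beyond the scatter, a lowering of the number is expected here as well, yet with the change at a different place it is expected to be smaller, at a 3.0-fold lower number from compound 3 to compound 4 (0.47 log units; beyond the scatter). Compound 4 is therefore estimated at 750 nM in this assay, between 250 nM and 2500 nM.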

Compound 4, half-maximal inhibitory concentration: 320 nM
Compound 4: the middle estimate sits 2.3-fold (0.37 log units) above what was measured, within the range that was stated.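

In this assay, the change gave a 6.9-fold lower number from compound 3 to compound 4 (0.84 log units; beyond the scatter), and this step matched the earlier one on the core of compound 1, so in these two pairs the change carried over from one core to the other at much the same size: the same change on two cores in this assay, a 7.3-fold lower number (0.86 log units; beyond the scatter) from compound 1 to compound 2 and a 6.9-fold lower number (0.84 log units; beyond the scatter) from compound 3 to compound 4, 1.0-fold (0.02 log units) apart, within the scatter of two such steps
This agreement holds even though the place of the change lies one bond further along the chain in the second pair. For the compounds shown here, it rests on only two pairs in a single cell line, however, and it does not show that the step would hold on any other core, nor does it separate the effect of exchanging the amine from that of lengthening the chain, since both pairs combine the two.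

The compounds shown leave open what 3-(diethylamino)propyl and 3-(dimethylamino)propyl would give on one and the same core, which would isolate the amine, and what a 2-(dimethylamino)ethyl chain would give, which would isolate the chain length. They also leave open whether a cyclic amine such as morpholine or piperidine at the chain end, or a chain longer than 4-(dimethylamino)butyl, would continue the trend.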